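The compounds below may be only part of what the source reports. "The series", "measured", "known", "first", "only" and "open" are said of these compounds alone.

Measured so far:
- compound 1, `Cc1ccc(CSc2nc3nc(C)cc(Nc4cc(-c5ccccc5)[nH]n4)n3n2)cc1`, in a functional assay on PC-9 cells (Homo sapiens) for inhibition, read by MTT assay, with a stated time of 72 h; a higher number here means a weaker inhibitor, a lower number a stronger inhibitor: 7310 nM
- compound 2, `Cc1cc(Nc2cc(-c3ccccc3)[nH]n2)n2nc(SCc3ccc(Cl)cc3)nc2n1`: 6710 nM
- compound 3, `Cc1cc(Nc2cc(-c3ccccc3)[nH]n2)n2nc(SCC3CC3)nc2n1`: > 50000 nM

Compound 3 gives only a limit of this assay, > 50000 nM, and no number, as the limit of > 50000 nM in this assay, at which 1 of the 3 values shown sits, records. It stands at the weak end of the three, since the steps from compound 1 and from compound 2 were an at least 6.8-fold higher number from compound 1 to compound 3 (0.83 log units; beyond the scatter) and an at least 7.4-fold higher number from compound 2 to compound 3 (0.87 log units; beyond the scatter), each at least modest, whereas compound 1 and compound 2 differ by a 1.1-fold lower number from compound 1 to compound 2 (0.04 log units; within the scatter).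

Compound 4, `C=CCSc1nc2nc(C)cc(Nc3cc(-c4ccccc4)[nH]n3)n2n1`, has not yet been measured. It differs from compound 3 by vinyl in place of cyclopropyl on a saturated chain carbon bound to a sulfur. Among the compounds with values here, no measured step covers a cyclopropyl to vinyl exchange on that chain carbon; the two steps that bear on the site show that removing the aryl group there costs potency, and vinyl, like cyclopropyl, is not an aryl group. Compound 4 is therefore expected to stay close to compound 3, with the step of a number no higher from compound 3 to compound 4 (the limit leaves the size open) expected to lie within the scatter, and the assay is likely to report only a limit again. Compound 4 is estimated at 50000 nM, between 15000 nM and 160000 nM.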

Compound 4, half-maximal inhibitory concentration: > 50000 nM
Compound 4 gave a limit, no number (the forecaster's own chance of this, stated with the estimate: 65%); the middle value lies on the limit itself.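

In this assay compound 4 stays at a limit, and it is the second compound with a small group in place of the aryl group on the saturated chain carbon bound to a sulfur to do so: the limit of > 50000 nM in this assay, at which 2 of the 4 values shown sit. Vinyl in place of 4-chlorophenyl gives an at least 7.4-fold higher number from compound 2 to compound 4 (0.87 log units; beyond the scatter) and vinyl in place of 4-methylphenyl gives an at least 6.8-fold higher number from compound 1 to compound 4 (0.83 log units; beyond the scatter) as well, so among these compounds the loss does not depend on the three-membered ring of cyclopropyl. The step between cyclopropyl and vinyl cannot be read, and the two groups remain unordered.

Open, from the compounds shown here alone, is how large the losses really are, since each is known only as a minimum. Also open, going by these compounds, is whether a longer chain, an amine or a pyridyl ring on that chain carbon would return a measurable number.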